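Quinazoline-diamine series: cyano for fluoro at compound 3

The compounds below may be only part of what the source reports. "The series", "measured", "known", "first", "only" and "open" are said of these compounds alone.

Of the compounds shown here, two have a value so far. Compound 1, `COCCCNc1nc(N)nc2ccccc12`, gives 0.01 uM in an ADME assay on HEK293 cells for agonist activity at Toll-like receptor 8 (Homo sapiens), read by a luciferase reporter, with a stated time of 6 h; on this read-out lower numbers stand for an effect already at smaller amounts and higher numbers for an effect only at larger amounts of compound. Compound 2, `CCCCNc1nc(N)nc2ccc(F)cc12`, gives 0.1 uM in the same assay. Compound 2 therefore stands at the highest of the two numbers, and its nearest neighbour is compound 1, whose number is lower by a gap that goes beyond the usual scatter. The two compounds differ in more than one place, so nothing about a single change can be drawn from that gap; only the two values themselves are known.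

Compound 3, `CCCCNc1nc(N)nc2ccc(C#N)cc12`, is not yet measured. It differs from compound 2 in one place: cyano in place of fluoro on an aromatic carbon. The fluoro leaves and a cyano enters on an aromatic carbon of a six-membered aromatic ring of carbon only, part of a fused system of two rings. Among the compounds with values here, no measured pair isolates this kind of change, so the expectation rests on the value of compound 2 alone. Compound 3 is expected to give about 0.1 uM in this assay, with a range from 0.03 uM to 0.5 uM. The step from compound 2 to compound 3 is thus expected to be no change at the digits printed from compound 2 to compound 3 (within the scatter), that is, no change beyond the scatter in either direction.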

Compound 3, minimum effective concentration: 7.1 uM
Estimate against measurement, compound 3: 71-fold (1.85 log units) below; measured number above the stated range.
By their numbers in this assay, from the lowest: compound 1; then compound 2; then compound 3.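

In this assay, this aromatic carbon, meta to a fused ring and para to a fused ring, does not tolerate every small group equally: cyano in place of fluoro brings a 71-fold higher number from compound 2 to compound 3 (1.85 log units; beyond the scatter). Within the data shown here, this is the first comparison that isolates one change, and with the rest of compound 2 kept intact, the whole step belongs to the exchange at this carbon, with the effect now appearing only at much larger amounts of compound. No measurement bears on why the exchange has this effect, and the two groups' counted differences, one heavy atom against two and no hydrogen-bond acceptor against one, remain a description and not an account of the step.

As far as these compounds go, it remains open whether the step reflects the arrival of cyano or the departure of fluoro, and whether a plain hydrogen, chloro, methoxy or an amine at this carbon would stay close to compound 2 or fall nearer compound 3. From the compounds shown here alone, it also remains open whether the same exchange would carry the same weight with the side chain of compound 1 in place of the chain shared by compound 2 and compound 3.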